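The compounds below may be only part of what the source reports. "The series", "measured", "known", "first", "only" and "open" are said of these compounds alone.

Three compounds share one core, differing only in the fused ring and its substituent. In an assay on Jurkat cells for displacement of a labelled ligand from Sigma non-opioid intracellular receptor 1 (Homo sapiens), read by scintillation counting, with a stated time of 120 min (a lower number here means a stronger inhibitor, a higher number a weaker inhibitor), compound 2 `CN(CCCn1c(=O)sc2ccccc21)Cc1ccccc1` gives 10.3 nM, the highest number of the three. Compound 1 `CN(CCCn1c(=O)oc2ccc(Cl)cc21)Cc1ccccc1` gives 6.4 nM, which lies within the usual scatter of compound 2, and compound 3 `CN(CCCn1c(=O)sc2cc(Br)ccc21)Cc1ccccc1` gives 0.6 nM. Within the data shown here, the one measured step, a 17-fold lower number from compound 2 to compound 3 (1.23 log units; beyond the scatter), is large. Compound 4 `CN(CCCn1c(=O)sc2ccc(Cl)cc21)Cc1ccccc1` differs from compound 2 by chloro in place of hydrogen on an aromatic carbon, a change that sits on the same ring as the bromo of compound 3. Among the measured compounds shown here, a lower number is therefore expected in this assay, with an expected step of about a 6.9-fold lower number from compound 2 to compound 4 (0.84 log units; beyond the scatter), because the only comparable step is a 17-fold lower number from compound 2 to compound 3 (1.23 log units; beyond the scatter). Compound 4 is estimated at 1.5 nM, with a range from 0.5 nM to 5 nM.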

Compound 4, inhibition constant: 4.7 nM
Estimate against measurement, compound 4: 3.1-fold (0.50 log units) below; measured number inside the range.
By their numbers in this assay, from the lowest: compound 3; then compounds 4, 1 and 2 (each within the scatter of the next, the first and the last beyond it).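

In this assay, chloro on this carbon, meta to a fused ring and para to a fused ring, gives a modest change, a 2.2-fold lower number from compound 2 to compound 4 (0.34 log units; beyond the scatter). This shows that one halogen at this place moves the number beyond the scatter, but compound 3 differs from compound 4 in both its halogen and its place, so neither difference can be singled out. Nothing available explains this step. Still open, going by these compounds, is how fluoro, methoxy or an amine would read on this carbon, and whether bromo here would match chloro.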